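The compounds below may be only part of what the source reports. "The series", "measured", "known", "first", "only" and "open" are said of these compounds alone.

Measured so far in a functional assay on L1210 cells (Mus musculus); a lower number here means a stronger inhibitor, a higher number a weaker inhibitor:

Compound 1 `CCCNC(=O)Nc1ccc(C(C)(C)C)cc1` gives 5400 nM
Compound 2 `CCNC(=O)Nc1ccc(C(C)CC)cc1` gives 43000 nM

Of these two, compound 2 at 43000 nM has the higher number, which makes it the weaker inhibitor, and its gap to compound 1 lies beyond the scatter. Compound 3 `CCCNC(=O)Nc1ccc(C(C)CC)cc1` has not yet been measured. It differs from compound 2 by a single change methyl in place of hydrogen on a saturated chain carbon, two bonds along the chain from an amide-type nitrogen in which a methyl takes the place of hydrogen on a saturated chain carbon, two bonds along the chain from an amide-type nitrogen. Ethylamino thus becomes propylamino.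

For the measured compounds named here, no measured pair shows this change alone. Going by the values given here, the only hint is that compound 1, which also carries propylamino, gives 5400 nM as the lower number, although it differs from compound 3 elsewhere. A modest move towards a lower number therefore seems likely, and the expected size is a 2.7-fold lower number from compound 2 to compound 3 (0.43 log units; beyond the scatter) in this assay, only slightly beyond the scatter. For compound 3 the estimated value is 16000 nM, with an expected range from 6000 nM to 40000 nM in this measurement.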

Compound 3, half-maximal inhibitory concentration: 30000 nM
Compound 3: middle estimate off by 1.9-fold (0.27 log units), on the low side; low and high end bracket the measured number.
By their numbers in this assay, from the lowest: compound 1; then compounds 3 and 2 (each within the scatter of the next).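

In this assay, for the compounds shown here, the first clean reading of methyl in place of hydrogen on a saturated chain carbon, two bonds along the chain from an amide-type nitrogen, is a 1.4-fold lower number from compound 2 to compound 3 (0.16 log units; within the scatter), so ethylamino and propylamino cannot be told apart here when sec-butyl is the other group. Going by these compounds alone, compound 3 also gives the first pair that isolates the other group: with propylamino held constant, sec-butyl in place of tert-butyl on an aromatic carbon gives a 5.6-fold higher number from compound 1 to compound 3 (0.74 log units; beyond the scatter), so of the two places where compound 1 and compound 2 differ, only this one shows a step clearly larger than the scatter in a one-place comparison. No measurement here explains why either step has the size it has.

The compounds shown leave open whether a longer chain, such as butylamino, or a chain ending in an amine or a carboxylic acid, would move the number beyond the scatter. They also leave open whether ethylamino and propylamino stay this close with tert-butyl on the aromatic carbon, and how a group such as isopropyl or cyclohexyl would compare there.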